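This account rests on a few compounds, and the source may have more. Where it says the series, first, only, none or still open, it means among the compounds named here.

Compound 1 `Ic1ccc(NC2=NCCO2)cc1` and compound 2 `Cc1ccc(NC2=NCCO2)cc1` share one core. In a functional assay on HT-29 cells (Homo sapiens) for inhibition, read by sulforhodamine B assay, with a stated time of 48 h (on this read-out higher numbers stand for weaker inhibition of growth and lower numbers for stronger inhibition of growth), compound 1 gives 1300 nM and compound 2 gives 13000 nM. The change between them is methyl in place of iodo on an aromatic carbon, and it made a step of a 10-fold higher number from compound 1 to compound 2 (1.00 log units; beyond the scatter). Compound 3 `O=C(CCl)NC(=O)Nc1ccc(I)cc1` rests on a different core; how the two cores differ is not broken down here. In this assay compound 3 gives 6900 nM. Compound 4 `Cc1ccc(NC(=O)NC(=O)CCl)cc1` carries the same kind of change on this second core, (methyl in place of iodo on an aromatic carbon); the surroundings differ, since the group stands para to a group of 6 heavy atoms in compound 2 but para to a group of 8 heavy atoms in compound 4. Because the earlier step of a 10-fold higher number from compound 1 to compound 2 (1.00 log units; beyond the scatter) lay beyond the scatter, a weakening is expected again, though it need not carry over fully. The step to compound 4 is expected to be a 6.5-fold higher number from compound 3 to compound 4 (0.81 log units; beyond the scatter). Compound 4 is therefore estimated at 45000 nM, within 12000 nM to 160000 nM.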

Compound 4, concentration for 50% growth inhibition: 10000 nM
Compound 4: middle estimate off by 4.5-fold (0.65 log units), on the high side; the whole stated range lies above it.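

On the core of compound 3, methyl in place of iodo gives a 1.4-fold higher number from compound 3 to compound 4 (0.16 log units; within the scatter), so this swap makes no clear difference there, unlike on the core of compound 1. The size of the step therefore did not carry over between the two cores in this assay: the same change on two cores in this assay, a 10-fold higher number (1.00 log units; beyond the scatter) from compound 1 to compound 2 and a 1.4-fold higher number (0.16 log units; within the scatter) from compound 3 to compound 4, 6.9-fold (0.84 log units) apart, beyond the scatter of two such steps This rests on a single pair of compounds per core, so it does not show how the swap would behave on any further core, nor why the two cores respond differently.

The compounds shown leave open how other groups at this place, such as an amine, a methoxy or an ethyl group, would compare on each core. They also leave open whether the same gap between the two steps would appear on other cells.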